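The source may report more compounds than this note shows. Statements on the series, on what has been measured and on what is new or still open speak of the compounds shown alone.

In a functional assay on DLA cells (Mus musculus) for cytotoxicity, read by LDH release, with a stated time of 48 h (on this read-out lower numbers stand for stronger inhibition and higher numbers for weaker inhibition), compound 1 `Cc1cc(C(=O)c2ccccc2)ccc1OCC(=O)Nc1nc(-c2ccccc2)cs1` gives 23000 nM, and its steps to the other two measured compounds stay within the scatter. Compound 2 `Cc1cc(C(=O)c2ccccc2)cc(C)c1OCC(=O)Nc1nc(-c2ccccc2)cs1` gives 19900 nM, and compound 3 `Cc1cc(C(=O)c2cccc(Br)c2)ccc1OCC(=O)Nc1nc(-c2ccccc2)cs1` gives 23600 nM. Unmeasured compound 4 `O=C(COc1ccc(C(=O)c2ccccc2)cc1Br)Nc1nc(-c2ccccc2)cs1` differs from compound 1 by bromo in place of methyl on an aromatic carbon, which is bromo in place of methyl on an aromatic carbon. For the measured compounds named here, no measured step makes this exact exchange. The nearest evidence is a 1.2-fold lower number from compound 1 to compound 2 (0.06 log units; within the scatter) for adding methyl and a 1.0-fold higher number from compound 1 to compound 3 (0.01 log units; within the scatter) for adding bromo. Both are small, so no change beyond the scatter is expected in this assay. The expected step is a 1.1-fold lower number from compound 1 to compound 4 (0.04 log units; within the scatter). Compound 4 is estimated at 21000 nM, with an expected range of 10000 nM to 40000 nM.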

Compound 4, half-maximal inhibitory concentration: 43500 nM
The estimate for compound 4 lay 2.1-fold (0.32 log units) below the measured number; the measured number lies above the stated range.
By their numbers in this assay, from the lowest: compounds 2, 1, 3 and 4 (each within the scatter of the next, the first and the last beyond it).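

At the aromatic carbon ortho to a large group and meta to a benzoyl group, bromo in place of methyl gives a 1.9-fold higher number from compound 1 to compound 4 (0.28 log units; within the scatter) in this assay. The earlier compounds shown here carried no bromo at this carbon, and this first exchange there does not move the number beyond the scatter. No available data account for the size of this step.

Open, going by these compounds, is whether an amine or a carboxylic acid at this carbon would give a step beyond the scatter in this assay. Also open, on these data alone, is what a longer chain in place of the methyl would do.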